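Chlorobenzyl sulfanyl series: positional chlorine swap

This account rests on a few compounds, and the source may have more. Where it says the series, first, only, none or still open, it means among the compounds named here.

Measured compounds:
compound 1, `COc1ccc(C2N=C(SCc3cccc(Cl)c3)NC(C)=C2C(=O)Nc2ccc(F)cc2)cc1OC`, 20.1%
compound 2, `COc1ccc(C2N=C(SCc3ccc(Cl)cc3)NC(C)=C2C(=O)Nc2ccc(F)cc2)cc1OC`, 37.1%
compound 3, `CC1=C(C(=O)Nc2ccc([N+](=O)[O-])cc2)C(c2cccc([N+](=O)[O-])c2)N=C(SCc2cccc(Cl)c2)N1`, 21.6%

All three were run in a functional assay on the whole organism (artery, strain albino) with Rattus norvegicus as the target, with a stated time of 360 min, at a dose of 10 mg/kg by the oral route; on this read-out higher numbers stand for more inhibition at the one dose given (going by the name of the read-out) and lower numbers for less inhibition. Compound 1 gives 20.1% and compound 2 gives 37.1%; the change between them is 4-chlorophenyl in place of 3-chlorophenyl on a saturated chain carbon bound to a sulfur, and the step reads a number 17 percentage points higher from compound 1 to compound 2 (beyond the scatter). Compound 3 gives 21.6% in this assay, which sits within the scatter of compound 1, so no order is read between those two. The difference between the core of compound 3 and the core of compound 1 is not broken down here.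

Compound 4, `CC1=C(C(=O)Nc2ccc([N+](=O)[O-])cc2)C(c2cccc([N+](=O)[O-])c2)N=C(SCc2ccc(Cl)cc2)N1`, is not yet measured in this assay. It differs from compound 3 by 4-chlorophenyl in place of 3-chlorophenyl on a saturated chain carbon bound to a sulfur, the same change, at the same place, as that from compound 1 to compound 2. For the measured compounds named here, only one occurrence of this change has been measured, so the expectation rests on a single step. For compound 4 a rise of about a number 12.4 percentage points higher from compound 3 to compound 4 (beyond the scatter) is expected, because a number 17 percentage points higher from compound 1 to compound 2 (beyond the scatter). Compound 4 is therefore estimated at 34%, with a range from 20% to 48%.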

Compound 4, a percentage reported as inhibition, in the whole organism at one dose (the size of the read-out at that dose, not a potency): 33%
For compound 4 the middle estimate is 1 percentage points above the measured one; low and high end bracket the measured number.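

In this assay, 4-chlorobenzyl in place of 3-chlorobenzyl on the sulfur of the second core gives a number 11.4 percentage points higher from compound 3 to compound 4 (beyond the scatter). Set beside the first core, the step keeps its direction and does not differ in size: the same change on two cores in this assay, a number 17 percentage points higher (beyond the scatter) from compound 1 to compound 2 and a number 11.4 percentage points higher (beyond the scatter) from compound 3 to compound 4, 5.6 percentage points apart, within the scatter of two such steps. Within this series the change therefore carries from one core to the other, but two cores are a narrow base, and nothing here shows that it would hold on a third core or explains why the 4-chlorobenzyl compounds read higher.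

Still open, on these data alone, is whether the chlorine matters at all, which a plain benzyl, a 4-fluorobenzyl or a 4-methoxybenzyl on the sulfur would begin to settle, as would a simple methyl in place of the whole benzyl group. The two cores also differ in more than one place, so the separate parts played by the groups that distinguish them remain unresolved, and an amine or a carboxylic acid on the amide aryl ring would probe that region further.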